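Bromine on the Phenyl Ring of an Imidazopyrazine Series

A few compounds are considered here, and "the series" means these few. Any claim that something is new, unique, unknown or untested is made for them only; others in the source may bear on it.

Compound 1 `c1ccc(-c2cn3ccnc3c(-c3ccc4ncn(C5CCCCC5)c4c3)n2)cc1` carries a phenyl group on its shared core. In a functional assay on SK-MEL-2 cells (Homo sapiens) for inhibition, read by sulforhodamine B assay, with a stated time of 48 h, tested at 10 uM (a higher number here means more inhibition at the concentration tested (going by the name of the read-out), a lower number less inhibition), compound 1 gives 16.5%, the highest of the three numbers measured here. Compound 2 `Fc1ccc(-c2cn3ccnc3c(-c3ccc4ncn(C5CCCCC5)c4c3)n2)cc1`, in which a fluoro replaces a hydrogen on that phenyl ring, gives 9.82%; the step of a number 6.7 percentage points lower from compound 1 to compound 2 (within the scatter) stays within the scatter. Compound 3 `c1cn2cc(-c3ccsc3)nc(-c3ccc4ncn(C5CCCCC5)c4c3)c2n1`, with a thiophen-3-yl in place of the phenyl, gives 3.68%; the step of a number 12.8 percentage points lower from compound 1 to compound 3 (beyond the scatter) is beyond the scatter, so the whole ring swap costs more than a single small substituent does.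

Compound 4 `Brc1ccc(-c2cn3ccnc3c(-c3ccc4ncn(C5CCCCC5)c4c3)n2)cc1` has not yet been measured. It differs from compound 1 by bromo in place of hydrogen on an aromatic carbon, the same kind of change as from compound 1 to compound 2, only with a larger halogen. Since the fluoro step a number 6.7 percentage points lower from compound 1 to compound 2 (within the scatter) stayed within the scatter, a bromo at the same position is expected to give no step beyond the scatter either, with a slight downward lean. Compound 4 is therefore estimated at 12%, between 0% and 26%, meaning an expected step of a number 4.5 percentage points lower from compound 1 to compound 4 (within the scatter).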

Compound 4, a percentage reported as inhibition, at one concentration (the size of the read-out at that concentration, not a potency): 24.1%
Beside the measured number, compound 4's estimate is 12.1 percentage points below it, and the stated range covers the measured number.
By their numbers in this assay, from the lowest: compounds 3, 2, 1 and 4 (each within the scatter of the next, the first and the last beyond it).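

The step of a number 7.6 percentage points higher from compound 1 to compound 4 (within the scatter) in this assay means that bromo, like fluoro, leaves no readable difference from hydrogen on this aromatic carbon, para to a large group. The two halogens do separate from each other, however: the step of a number 14.3 percentage points higher from compound 2 to compound 4 (beyond the scatter) shows that the choice of halogen can matter even though neither differs clearly from hydrogen. The step of a number 20.4 percentage points higher from compound 3 to compound 4 (beyond the scatter) also lies clearly outside the usual variation, so 4-bromophenyl and thiophen-3-yl are distinct at this place on the shared core.

Nothing available here explains why bromo and fluoro differ. On these data alone, it also remains open whether a chloro, a methoxy or an amine at the same carbon would fall with bromo, with fluoro or elsewhere.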